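From Methoxy to Butoxy on a Shared Core

The compounds below may be only part of what the source reports. "The series", "measured", "known", "first", "only" and "open" are said of these compounds alone.

In a functional assay on HCT-116 cells (Homo sapiens) for inhibition, read by sulforhodamine B assay, with a stated time of 48 h, tested at 50 uM (on this read-out lower numbers stand for less inhibition of growth and higher numbers for more inhibition of growth at the one concentration tested), compound 1 (`COc1cc2c(cc1CCC(C)C)C(=O)C[C@@H](c1ccc(O)cc1)O2`) gives 77% and compound 2 (`COc1ccc([C@@H]2CC(=O)c3cc(CC=C(C)C)c(OC)cc3O2)cc1`) gives 68% at the single concentration tested. These two readings lie within the usual scatter of each other, so neither compound can be ranked above the other. Compound 3 (`CCCCOc1ccc([C@@H]2CC(=O)c3cc(CC=C(C)C)c(OC)cc3O2)cc1`) differs from compound 2 in one place, by the change propyl in place of hydrogen on a saturated chain carbon bound to an oxygen on an aromatic ring on a saturated chain carbon bound to an oxygen on an aromatic ring, so that methoxy becomes butoxy. Among the measured compounds shown here, no two measured compounds differ in only one place, so no measured step guides the expectation. In this assay no step beyond the scatter is expected, and the estimated a number 3 percentage points lower from compound 2 to compound 3 (within the scatter) is small. In this assay compound 3 is expected to give 65% with an estimated range of 50% to 79% around that middle.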

Compound 3, percent growth inhibition at one concentration: 60%
The estimate for compound 3 lay 5 percentage points above the measured number; the measured number falls inside the stated range.
By their numbers in this assay, from the lowest: compounds 3, 2 and 1 (each within the scatter of the next, the first and the last beyond it).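

Among the compounds shown here, replacing methoxy with butoxy on a saturated chain carbon bound to an oxygen on an aromatic ring gives the only single-place step available in this assay (a number 8 percentage points lower from compound 2 to compound 3 (within the scatter)). At this position, then, the added propyl leaves the reading of the butoxy compound within the scatter of its methoxy partner, and compound 3 still shows substantial growth inhibition at the one concentration tested. Nothing measured here accounts for this reading.

On these data alone, whether a chain longer than butyl, or an amine or a carboxylic acid at the end of this chain, would read differently remains open. As far as these compounds go, it also remains open whether the step between these two compounds would look the same at other concentrations.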